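The source may hold more compounds than are shown below. What is called first, only, known or untested is meant among the compounds shown, and "the series" means these compounds.

Values in a functional assay on RAW264.7 cells (Mus musculus) for inhibition, read by Griess assay, with stated times of 1 h and 24 h (a lower number here means a stronger inhibitor, a higher number a weaker inhibitor), are these:

compound 1 `CCOc1ccc(C(O)C2OC(=O)c3c(OC)cc(OC)cc32)cc1` gives > 10000 nM as a limit of the assay
compound 2 `CCCOc1ccc(C(O)C2OC(=O)c3c(OC)cc(OC)cc32)cc1` gives 9260 nM as a number
compound 3 `CCC(C)Oc1ccc(C(O)C2OC(=O)c3c(OC)cc(OC)cc32)cc1` gives > 10000 nM as a limit of the assay

Compound 3 therefore has only a limit and no number. The short series sits largely at the limit of > 10000 nM in this assay, at which 2 of the 3 values shown sit, and this leaves little room to read its steps.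

Compound 4 `COCCCOc1ccc(C(O)C2OC(=O)c3c(OC)cc(OC)cc32)cc1` has not yet been measured. It carries 3-methoxypropyl in place of sec-butyl on an oxygen on an aromatic ring.

The measured steps that bear on this change all alter the chain on that same kind of oxygen. They read (an at least 1.0-fold lower number from compound 1 to compound 2 (0.03 log units; that floor lies within the scatter)) and (an at least 1.0-fold higher number from compound 2 to compound 3 (0.03 log units; that floor lies within the scatter)) and (a step that the two limits leave unreadable from compound 1 to compound 3) so none of them is a readable step beyond the scatter. Among the compounds with values here, compound 2 at 9260 nM is the only number. On these data alone, no chain like 3-methoxypropyl has been measured, so the direction stays open and no step beyond the scatter is expected in this assay here. The expected step is (a number no higher from compound 3 to compound 4 (the limit leaves the size open)) and it remains an estimate. For compound 4 the estimated value is 10000 nM with an expected range from 4500 nM to 22000 nM in this measurement.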

Compound 4, half-maximal inhibitory concentration: 1260 nM
Compound 4: middle estimate off by 7.9-fold (0.90 log units), on the high side, and the stated range ends above it.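

In this assay, the chain on the oxygen on an aromatic ring now gives a readable step beyond the scatter, which none of the earlier changes there did. Within the data shown here, the one step between two true numbers is a 7.3-fold lower number from compound 2 to compound 4 (0.87 log units; beyond the scatter), and it comes with methoxy in place of hydrogen on a saturated chain carbon, three bonds along the chain from that oxygen. The other two steps are an at least 7.9-fold lower number from compound 3 to compound 4 (0.89 log units; beyond the scatter) and an at least 7.9-fold lower number from compound 1 to compound 4 (0.89 log units; beyond the scatter), and their sizes are only floors, since each starts from a limit: the limit of > 10000 nM in this assay, at which 2 of the 4 values shown sit.

On these data alone, whether the gain comes from the oxygen in the chain itself or from the length of the chain stays open, and a plain butyl or pentyl chain, a 2-methoxyethyl chain or a terminal amine on the same oxygen would help to separate the two. How far the number could fall with a longer ether chain, and why 3-methoxypropyl stands apart from the three plain chains, also remain unanswered by the compounds shown.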